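The source may hold more compounds than are shown below. What is called first, only, known or untested is meant among the compounds shown, and "the series" means these compounds.

Measured compounds:
Compound 1 `CCCC(=O)N1CCC(NS(=O)(=O)c2ccc(NC(=O)CC3CCCC3)c3ccccc23)CC1` gives 145 nM in an in vitro functional assay on CHO/Galpha16 cells for antagonist activity at C-C chemokine receptor type 8 (Homo sapiens), read by FLIPR; on this read-out lower numbers stand for stronger inhibition and higher numbers for weaker inhibition.
Compound 2 `CCCC(=O)N1CCC(NS(=O)(=O)c2ccc(NC(=O)c3cccc(C)c3)c3ccccc23)CC1` gives 5.1 nM in this assay.
Compound 3 `CCCC(=O)N1CCC(NS(=O)(=O)c2ccc(NC(=O)c3ccc(C)cc3)c3ccccc23)CC1` gives 9.5 nM in this assay.

Among the three measured compounds, compound 3 holds the second highest number: the step of a 1.9-fold higher number from compound 2 to compound 3 (0.27 log units; within the scatter) lies within the scatter, while the step of a 15-fold lower number from compound 1 to compound 3 (1.18 log units; beyond the scatter) is beyond it. The large gains seen in a 28-fold lower number from compound 1 to compound 2 (1.45 log units; beyond the scatter) and a 15-fold lower number from compound 1 to compound 3 (1.18 log units; beyond the scatter) both came from trading the cyclopentylmethyl for a methylphenyl on the carbonyl carbon.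

Compound 4 `CCCC(=O)N1CCC(NS(=O)(=O)c2ccc(NC(=O)c3ccc(CC)cc3)c3ccccc23)CC1` is not yet measured. It differs from compound 3 by methyl in place of hydrogen on a saturated chain carbon bound to an aromatic carbon. Among the compounds with values here, none of the measured steps changes the length of a chain on the aromatic ring; the nearest in kind, a 1.9-fold higher number from compound 2 to compound 3 (0.27 log units; within the scatter), moves the methyl on the ring and stays within the scatter. Within the data shown here, with no measured step speaking for a shift in either direction, the expectation for compound 4 is a step of a 1.1-fold higher number from compound 3 to compound 4 (0.02 log units; within the scatter) that stays within the scatter. Compound 4 is therefore estimated at 10 nM, with a range from 4 nM to 25 nM, in this assay.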

Compound 4, half-maximal inhibitory concentration: 10.8 nM
Estimate against measurement, compound 4: 1.1-fold (0.03 log units) below; the range from low to high includes it.
By their numbers in this assay, from the lowest: compounds 2, 3 and 4 (each within the scatter of the next, the first and the last beyond it); then compound 1.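

Going from 4-methylphenyl to 4-ethylphenyl gives a 1.1-fold higher number from compound 3 to compound 4 (0.06 log units; within the scatter) in this assay and so shows, as no earlier step did, that a methyl added on this saturated chain carbon bound to an aromatic carbon costs nothing measurable. The ethyl compound also keeps the large gain over the cyclopentylmethyl group, with a 13-fold lower number from compound 1 to compound 4 (1.13 log units; beyond the scatter) as the step, while the comparison with the 3-methylphenyl group gives a 2.1-fold higher number from compound 2 to compound 4 (0.33 log units; beyond the scatter) and so a modest gap that only just clears the scatter. Nothing available here explains why the numbers fall as they do.

The compounds shown leave open whether a longer chain such as propyl, or a chain ending in an amine or a carboxylic acid, would stay in this range. They also leave open whether a 3-ethylphenyl group would behave like the 4-ethylphenyl group.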